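Swapping chloro for bromo on a growth-inhibiting sulfone

A few compounds are considered here, and "the series" means these few. Any claim that something is new, unique, unknown or untested is made for them only; others in the source may bear on it.

Measured in a functional assay on DU-145 cells (Homo sapiens) for inhibition, read by trypan blue exclusion, with a stated time of 96 h (on this read-out lower numbers stand for stronger inhibition of growth and higher numbers for weaker inhibition of growth), so far:
compound 1 (`Cc1cc(C)cc(/C=C(\C(=O)c2ccc(Br)cc2)S(=O)(=O)Cc2ccc(F)cc2)c1`): 10000 nM
compound 2 (`O=C(/C(=C\c1ccc(O)cc1)S(=O)(=O)Cc1ccc(F)cc1)c1ccc(Br)cc1`): 10000 nM
compound 3 (`O=C(/C(=C\c1ccc(Br)cc1)S(=O)(=O)Cc1ccc(F)cc1)c1ccc(Cl)cc1`): > 100000 nM (a limit)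

Compound 3 reports only a limit, > 100000 nM (not a number). Compound 4 (`O=C(/C(=C\c1ccc(Br)cc1)S(=O)(=O)Cc1ccc(F)cc1)c1ccc(Br)cc1`) replaces its 4-chlorophenyl with 4-bromophenyl, bromo in place of chloro on an aromatic carbon. No such swap has been measured. Going by the values given here, the one measured step, no change at the digits printed from compound 1 to compound 2 (within the scatter), lies elsewhere and bears only indirectly. Compound 4 shares its (4-bromophenyl)carbonyl with compound 2, which gives 10000 nM in this assay, so stronger inhibition than that of compound 3 is expected. The expected change is an at least 5.0-fold lower number from compound 3 to compound 4 (0.69 log units; beyond the scatter) on this estimate. For compound 4 the estimated value is 20000 nM within an expected range from 3000 nM to 100000 nM overall.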

Compound 4, concentration for 50% growth inhibition: 25000 nM
The estimate for compound 4 lay 1.3-fold (0.10 log units) below the measured number; low and high end bracket the measured number.
By their numbers in this assay, from the lowest: compounds 1 and 2 (each within the scatter of the next); then compound 4. At a limit, above all of these: compound 3.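

In this assay, bromo in place of chloro on the aromatic carbon gives an at least 4.0-fold lower number from compound 3 to compound 4 (0.60 log units; beyond the scatter). Compound 3 stands at a limit, so this step is a bound rather than a measured size: the limit of > 100000 nM in this assay, at which 1 of the 4 values shown sits. With that bromo in place, the other aryl group also moves the number: bromo in place of hydroxy gives a 2.5-fold higher number from compound 2 to compound 4 (0.40 log units; beyond the scatter), and 4-bromophenyl in place of 3,5-dimethylphenyl gives a 2.5-fold higher number from compound 1 to compound 4 (0.40 log units; beyond the scatter).

The compounds shown leave open whether fluoro on that aromatic carbon would track chloro or bromo. They also leave open whether an amine or a methoxy group there would lower the number further.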